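The source may hold more compounds than are shown below. What is called first, only, known or untested is meant among the compounds shown, and "the series" means these compounds.

Measured so far:
- Compound 1 `Cc1ccc(C(=O)Nc2cccc(C(F)(F)F)c2)cc1-c1ccc2c(-c3cn[nH]c3)n[nH]c2c1` gives > 1000 nM in a functional assay on NCI-H2286 cells (Homo sapiens) for antiproliferative activity, read by CCK-8 assay, with a stated time of 72 h; a lower number here means a stronger inhibitor, a higher number a weaker inhibitor; this is a limit of the assay, not a number.
- Compound 2 `CCn1cc(-c2n[nH]c3cc(-c4cc(C(=O)Nc5cccc(C(F)(F)F)c5)ccc4C)ccc23)cn1` gives 19.8 nM in this assay.
- Compound 3 `Cc1ccc(C(=O)Nc2cccc(C(F)(F)F)c2)cc1-c1ccc2c(-c3cnn(C4CC4)c3)n[nH]c2c1` gives 93 nM in this assay.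

Among the two numbers shown, compound 3 stands highest: a 4.7-fold higher number from compound 2 to compound 3 (0.67 log units; beyond the scatter). Compound 1 sits at a limit (the limit of > 1000 nM in this assay, at which 1 of the 3 values shown sits), so its distance from compound 3 is known only to be an at least 10-fold lower number from compound 1 to compound 3 (1.03 log units; beyond the scatter).

Compound 4 `Cc1ccc(C(=O)Nc2cccc(C(F)(F)F)c2)cc1-c1ccc2c(-c3cnn(CC(C)O)c3)n[nH]c2c1` has not yet been measured in this assay. It differs from compound 3 in one place: 2-hydroxypropyl in place of cyclopropyl on an aromatic nitrogen.

Among the compounds with values here, two measured steps bear on this position. Replacing hydrogen on the aromatic nitrogen by cyclopropyl gave an at least 10-fold lower number from compound 1 to compound 3 (1.03 log units; beyond the scatter), and replacing ethyl by cyclopropyl gave a 4.7-fold higher number from compound 2 to compound 3 (0.67 log units; beyond the scatter). Both show that the group on this nitrogen matters, and that a chain such as ethyl in compound 2 gave a lower number than cyclopropyl in compound 3. The 2-hydroxypropyl group is also a chain, though it carries a hydroxyl that neither ethyl nor cyclopropyl has, so its effect is less certain.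

Compound 4 is therefore expected to give a somewhat lower number than compound 3, a 2.1-fold lower number from compound 3 to compound 4 (0.32 log units; beyond the scatter), with the estimate for compound 4 at 45 nM, between 12 nM and 180 nM.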

Compound 4, half-maximal inhibitory concentration: 196 nM
Compound 4: the middle estimate sits 4.4-fold (0.64 log units) below what was measured; the measured number lies above the stated range.
By their numbers in this assay, from the lowest: compound 2; then compound 3; then compound 4. At a limit, above all of these: compound 1.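

Turning the ethyl group into 2-hydroxypropyl, by putting 1-hydroxyethyl in place of its methyl end, gives a 9.9-fold higher number from compound 2 to compound 4 (1.00 log units; beyond the scatter) in this assay, so the chain length and hydroxyl tolerated on this nitrogen are limited. Against cyclopropyl, the 2-hydroxypropyl group gives a 2.1-fold higher number from compound 3 to compound 4 (0.32 log units; beyond the scatter), which means that the earlier lead of a chain over cyclopropyl holds for ethyl in compound 2 and is reversed by 2-hydroxypropyl in compound 4. Even so, 2-hydroxypropyl in place of hydrogen still gives an at least 5.1-fold lower number from compound 1 to compound 4 (0.70 log units; beyond the scatter), a step that is only a bound, as compound 1 stands at a limit and not at a number: the limit of > 1000 nM in this assay, at which 1 of the 4 values shown sits.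

The compounds shown cannot tell whether the higher number of compound 4 comes from the hydroxyl or from the extra chain length, and a plain propyl group on this nitrogen would separate the two. A methyl group, a methoxy-bearing chain or an amine at the end of the chain would show how far this position follows the same trend.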